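A few compounds are considered here, and "the series" means these few. Any claim that something is new, unique, unknown or untested is made for them only; others in the source may bear on it.

Compound 2 `CCOc1ncc(-c2nc(C(F)(F)F)sc2N2CCN(C(=O)Cn3cnc4cccnc43)[C@H](C)C2)cn1` gives 20 nM in a functional assay on U2OS cells for antagonist activity at C-X-C chemokine receptor type 3 (Homo sapiens), read by beta-arrestin recruitment (a lower number here means a stronger inhibitor, a higher number a weaker inhibitor), the lowest of the two numbers recorded; its nearest neighbour, compound 1 `C[C@@H]1CN(c2sc(C(F)(F)F)nc2-c2nc3ccccc3[nH]2)CCN1C(=O)Cn1cnc2cccnc21`, gives 31 nM in this assay, and the step of a 1.6-fold lower number from compound 1 to compound 2 (0.19 log units; within the scatter) lies within the scatter. Compound 3 `CCOc1ncc(-c2nc(C(F)(F)F)sc2N2CCN(C(=O)Cn3ncc4cccnc43)[C@H](C)C2)cn1` has not yet been measured. It differs from compound 2 by a group of 9 heavy atoms (6 carbon, 3 nitrogen; one five-membered aromatic ring with 2 hetero atoms, one six-membered aromatic ring with 1 hetero atom) in place of a group of 9 heavy atoms (6 carbon, 3 nitrogen; one five-membered aromatic ring with 2 hetero atoms, one six-membered aromatic ring with 1 hetero atom), on a saturated chain carbon bound to a carbonyl carbon. For the measured compounds named here, the one measured step, a 1.6-fold lower number from compound 1 to compound 2 (0.19 log units; within the scatter), concerns the group on an aromatic carbon and not the saturated chain carbon bound to a carbonyl carbon, so no measured step bears directly on the change from compound 2 to compound 3. With nothing in the numbers pointing either way, the step of a 1.3-fold higher number from compound 2 to compound 3 (0.10 log units; within the scatter) is expected to be none beyond the scatter. Compound 3 is therefore estimated to give 25 nM in this assay, within a range from 8 nM to 80 nM.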

Compound 3, half-maximal inhibitory concentration: 55 nM
For compound 3 the middle estimate is 2.2-fold (0.34 log units) below the measured one; the measured number falls inside the stated range.
By their numbers in this assay, from the lowest: compounds 2, 1 and 3 (each within the scatter of the next, the first and the last beyond it).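

In this assay the exchange of one group for the other on a saturated chain carbon bound to a carbonyl carbon gives a clear move (a 2.8-fold higher number from compound 2 to compound 3 (0.44 log units; beyond the scatter)), whereas the earlier step on an aromatic carbon stayed within the scatter. The leaving and entering groups have the same atoms, the same ring types and the same counts of hydrogen-bond donors and acceptors, so this position responds to how those atoms are joined, at least in this one pair. Nothing measured here explains the difference.

From the compounds shown here alone, whether the same exchange moves the number to a similar extent with 1H-benzimidazol-2-yl on the aromatic carbon stays open. So does the outcome of placing a plain phenyl ring or a dimethylamino group on the saturated chain carbon bound to a carbonyl carbon.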